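Adding a Methoxy Group Next to the Phenolic Hydroxyl

The compounds below may be only part of what the source reports. "The series", "measured", "known", "first", "only" and "open" are said of these compounds alone.

Of the compounds shown here, three sharing one core have been tested in a functional assay on NCI-H460 cells (Homo sapiens) for cytotoxicity, read by MTT assay, with a stated time of 72 h; on this read-out lower numbers stand for stronger inhibition and higher numbers for weaker inhibition. Compound 1 `CN(C)CCn1cnnc1-c1cc(Oc2ccc(NC(=O)N/N=C/c3ccc(F)cc3)cc2F)ccn1` gives 1980 nM, compound 2 `CN(C)CCn1cnnc1-c1cc(Oc2ccc(NC(=O)N/N=C/c3cc(Br)c(O)c(Br)c3)cc2F)ccn1` gives 3760 nM, and compound 3 `CN(C)CCn1cnnc1-c1cc(Oc2ccc(NC(=O)N/N=C/c3ccc(O)cc3)cc2F)ccn1` gives 1780 nM. Among the compounds with values here, compound 3 has the lowest of the three numbers, although the step of a 1.1-fold lower number from compound 1 to compound 3 (0.05 log units; within the scatter) lies within the scatter, so compound 1 and compound 3 cannot be told apart; only the step of a 2.1-fold lower number from compound 2 to compound 3 (0.32 log units; beyond the scatter) is modest but beyond the scatter, and the step of a 1.9-fold higher number from compound 1 to compound 2 (0.28 log units; within the scatter) stays within the scatter.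

Compound 4 `COc1cc(/C=N/NC(=O)Nc2ccc(Oc3ccnc(-c4nncn4CCN(C)C)c3)c(F)c2)ccc1O` differs from compound 3 by one change: methoxy in place of hydrogen on an aromatic carbon, on an aromatic carbon, ortho to a hydroxy group and meta to a large group. All three measured steps involve this same ring, and each was small or within the scatter, with flanking groups beside the hydroxy giving only a modest rise in compound 2. Compound 4 is therefore expected to show no step beyond the scatter, at most a slight rise, which is the step of a 1.2-fold higher number from compound 3 to compound 4 (0.09 log units; within the scatter). The estimate for compound 4 in this assay is 2200 nM, with a range from 1000 nM to 5000 nM.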

Compound 4, half-maximal inhibitory concentration: 57 nM
Beside the measured number, compound 4's estimate is 39-fold (1.59 log units) above it; measured number below the stated range.
By their numbers in this assay, from the lowest: compound 4; then compounds 3, 1 and 2 (each within the scatter of the next, the first and the last beyond it).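

In this assay, methoxy on this aromatic carbon, ortho to a hydroxy group, produces a large step (a 31-fold lower number from compound 3 to compound 4 (1.49 log units; beyond the scatter)), whereas the earlier changes on this ring stayed within the scatter or only modestly beyond it. The 4-hydroxy-3-methoxyphenyl group also stands far from both earlier groups (a 66-fold lower number from compound 2 to compound 4 (1.82 log units; beyond the scatter); a 35-fold lower number from compound 1 to compound 4 (1.54 log units; beyond the scatter)), so the 3,5-dibromo-4-hydroxyphenyl group of compound 2 gave no hint of what this single methoxy would do. Nothing available here accounts for the size of this step.

The compounds shown leave open whether the hydroxy group must remain for the methoxy to have this effect, and whether an ethoxy group or an amine on the same carbon would act alike. They also leave open whether the step carries over to other cell types.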